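A few compounds are considered here, and "the series" means these few. Any claim that something is new, unique, unknown or untested is made for them only; others in the source may bear on it.

Compound 1 `CN(C)CCCNc1nc2cc([N+](=O)[O-])ccc2nc1NCc1ccc(Br)cc1`: 9.63 ug/mL
Compound 2 `CN(C)CCCNc1nc2cc([N+](=O)[O-])ccc2nc1NCc1ccc(Cl)cc1`: 10.7 ug/mL
Compound 3 `CN(C)CCCNc1nc2cc([N+](=O)[O-])ccc2nc1NCc1ccc(F)cc1`: 4.28 ug/mL

In an ADME assay on HEK293 cells (Homo sapiens) for cytotoxicity, read by MTT assay, with a stated time of 24 h (on this read-out lower numbers stand for stronger inhibition and higher numbers for weaker inhibition), compound 3 gives the lowest of the three numbers, 4.28 ug/mL. Compound 4 `Cc1ccc(CNc2nc3ccc([N+](=O)[O-])cc3nc2NCCCN(C)C)cc1` differs from it by one change: methyl in place of fluoro on an aromatic carbon. For the measured compounds named here, no methyl compound has been measured, so the evidence is indirect. Two modest steps bear on it, a 2.3-fold lower number from compound 1 to compound 3 (0.35 log units; beyond the scatter) and a 2.5-fold lower number from compound 2 to compound 3 (0.40 log units; beyond the scatter), while a 1.1-fold higher number from compound 1 to compound 2 (0.05 log units; within the scatter) stays within the scatter. Both bromo and chloro thus stand above fluoro, and methyl is expected to do the same. The expected move in this assay is a 1.9-fold higher number from compound 3 to compound 4 (0.27 log units; within the scatter), a modest rise. Compound 4 is estimated at 8 ug/mL, with an expected range of 4 ug/mL to 15 ug/mL.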

Compound 4, half-maximal inhibitory concentration: 15.8 ug/mL
Beside the measured number, compound 4's estimate is 2.0-fold (0.30 log units) below it, outside the stated range (above it).
By their numbers in this assay, from the lowest: compound 3; then compounds 1, 2 and 4 (each within the scatter of the next).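

Here a 3.7-fold higher number from compound 3 to compound 4 (0.57 log units; beyond the scatter) is the largest step for a single change at this position in this assay so far, and it shows that a carbon group can stand as far from fluoro as the heavier halogens do. Methyl cannot be told from chloro or bromo: a 1.5-fold higher number from compound 2 to compound 4 (0.17 log units; within the scatter) and a 1.6-fold higher number from compound 1 to compound 4 (0.22 log units; within the scatter) both stay within the scatter, which leaves fluoro alone apart from the other three groups. Going by these compounds, whether a methoxy, a hydroxyl or a trifluoromethyl at this place would side with fluoro or with the other three stays open. Nothing measured here accounts for the separate standing of fluoro.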